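Bromobenzyl to Bromophenyl on the Ring Nitrogen

The source may hold more compounds than are shown below. What is called first, only, known or untested is meant among the compounds shown, and "the series" means these compounds.

Within the data shown here, compound 3 `CCCn1c(=O)[nH]c2nc(-c3ccc(S(=O)(=O)N4CCN(Cc5cccc(Br)c5)CC4)cc3)[nH]c2c1=O` is the only member of this small set with a true number in an assay on CHO cells for displacement of a labelled ligand from adenosine receptor A1 (Homo sapiens), read by scintillation counting, with a stated time of 90 min, in the presence of a further agent that is not named here; a higher number here means a weaker inhibitor, a lower number a stronger inhibitor: compound 3 gives 928 nM. Compound 1 `CCCn1c(=O)[nH]c2nc(-c3ccc(S(=O)(=O)N4CCN(c5ccc(F)cc5)CC4)cc3)[nH]c2c1=O` carries a 4-fluorophenyl on the same ring nitrogen, and in this assay compound 1 reaches the limit > 1000 nM, a limit of the measurement rather than a number. Compound 2 `CCCn1c(=O)[nH]c2nc(-c3ccc(S(=O)(=O)N4CCN(c5ccc(Cl)cc5F)CC4)cc3)[nH]c2c1=O`, with a 4-chloro-2-fluorophenyl there, likewise gives only the limit > 1000 nM. The steps of an at least 1.0-fold lower number from compound 1 to compound 3 (0.03 log units; that floor lies within the scatter) and an at least 1.0-fold lower number from compound 2 to compound 3 (0.03 log units; that floor lies within the scatter) therefore set only a floor, and that floor lies within the scatter; what they share is that the benzyl group yields a readable number where the two aryl groups placed directly on the nitrogen do not, as the limit of > 1000 nM in this assay, at which 2 of the 3 values shown sit, records. Compound 4 `CCCn1c(=O)[nH]c2nc(-c3ccc(S(=O)(=O)N4CCN(c5ccccc5Br)CC4)cc3)[nH]c2c1=O` is not yet measured; it differs from compound 3 by 2-bromophenyl in place of 3-bromobenzyl on an amine nitrogen in a ring. That change returns to an aryl group directly on the ring nitrogen, the arrangement seen in compounds 1 and 2. Compound 4 is therefore expected to bind more weakly, with an estimated step of a 2.2-fold higher number from compound 3 to compound 4 (0.33 log units; beyond the scatter). The estimate for compound 4 is 2000 nM, in a range from 700 nM to 6000 nM, with a real chance that only a limit is reported.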

Compound 4, inhibition constant: > 1000 nM
Compound 4: no number, only a limit (the forecaster's own chance of this, stated with the estimate: 65%); the middle value is on the limit's open side.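

In this assay compound 4 gives > 1000 nM, a limit of the measurement and not a number. The step of an at least 1.0-fold higher number from compound 3 to compound 4 (0.03 log units; that floor lies within the scatter) sets only a floor, so it does not establish that 2-bromophenyl binds more weakly than 3-bromobenzyl, and the steps joining compound 1, compound 2 and compound 4 cannot be read. What is new is that a third aryl group placed directly on the ring nitrogen also gives no readable number, leaving the 3-bromobenzyl of compound 3 as the only group here with one: the limit of > 1000 nM in this assay, at which 3 of the 4 values shown sit.

From the compounds shown here alone, how far the three aryl compounds actually lie from compound 3 stays open, and a single benzyl compound cannot show whether benzyl groups in general give readable values. Nor do the compounds shown tell what an unsubstituted benzyl or a longer chain such as phenethyl would give on this nitrogen.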